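The source may report more compounds than this note shows. Statements on the series, on what has been measured and on what is new or still open speak of the compounds shown alone.

Three related compounds have been tested in an assay for inhibition of Indoleamine 2,3-dioxygenase 1 (Homo sapiens), read by spectrophotometry, with stated times of 1 h and 4 h; on this read-out higher numbers stand for weaker inhibition and lower numbers for stronger inhibition. Compound 2 `CC(=O)Nc1ccc(S(=O)(=O)NNc2ccc(Br)cc2)cc1` gives 130 nM in this assay. Compound 1 `CC(=O)Nc1ccc(S(=O)(=O)NNc2ccc(C#N)cc2)cc1` carries cyano in place of bromo on an aromatic carbon and gives 5670 nM; the step of a 44-fold higher number from compound 2 to compound 1 (1.64 log units; beyond the scatter) is large, toward weaker inhibition. Compound 3 `O=S(=O)(NNc1ccc(Br)cc1)c1ccc(Br)cc1` differs from compound 2 by bromo in place of acetamido on an aromatic carbon; compound 3 gives 85 nM; the step of a 1.5-fold lower number from compound 2 to compound 3 (0.18 log units; within the scatter) stays within the scatter, so the two cores behave alike. Compound 4 `N#Cc1ccc(S(=O)(=O)NNc2ccc(Br)cc2)cc1` has not yet been measured. It carries the same change as compound 1, (cyano in place of bromo on an aromatic carbon), now made on the core of compound 3. Because the step of a 44-fold higher number from compound 2 to compound 1 (1.64 log units; beyond the scatter) was so large, compound 4 is expected to show a step of a 41-fold higher number from compound 3 to compound 4 (1.61 log units; beyond the scatter) in this assay. Compound 4 is therefore estimated at 3500 nM, probably between 1000 nM and 12000 nM.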

Compound 4, half-maximal inhibitory concentration: 176 nM
For compound 4 the middle estimate is 20-fold (1.30 log units) above the measured one; measured number below the stated range.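

In this assay, the new step for cyano in place of bromo on an aromatic carbon is only modest, a 2.1-fold higher number from compound 3 to compound 4 (0.32 log units; beyond the scatter), while cyano in place of acetamido stays within the scatter, a 1.4-fold higher number from compound 2 to compound 4 (0.13 log units; within the scatter). The same change therefore does not keep its size from one core to the other: the same change on two cores in this assay, a 44-fold higher number (1.64 log units; beyond the scatter) from compound 2 to compound 1 and a 2.1-fold higher number (0.32 log units; beyond the scatter) from compound 3 to compound 4, 21-fold (1.32 log units) apart, beyond the scatter of two such steps This shows that a step measured on one core cannot simply be transferred to the other here, but it does not show why, and two pairs set no rule for the whole series. Still open, on these data alone, is how the change behaves when an amine or a carboxylic acid stands in place of the acetamido or bromo of these cores. As far as these compounds go, whether a further core would follow the large step or the modest one also remains unknown.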